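From methoxycarbonyl to propoxycarbonyl at compound 3

The source may hold more compounds than are shown below. What is called first, only, known or untested is meant among the compounds shown, and "the series" means these compounds.

For the measured compounds named here, in a functional assay on RAW264.7 cells (Mus musculus) for inhibition (on this read-out lower numbers stand for stronger inhibition and higher numbers for weaker inhibition), compound 1 `CCOC(=O)C1=CCCCC1S(=O)(=O)Nc1c(F)cccc1F` gives 160 nM and so holds the highest number of the three measured so far. Compound 2 `CCOC(=O)C1=CCCCC1S(=O)(=O)Nc1ccc(F)cc1F` gives 16 nM and holds the lowest. Compound 3 `COC(=O)C1=CCCCC1S(=O)(=O)Nc1ccc(F)cc1F` lies in the middle at 57 nM on this read-out.

Compound 4 `CCCOC(=O)C1=CCCCC1S(=O)(=O)Nc1ccc(F)cc1F` has not been measured yet. It differs from compound 3 in one place: ethyl in place of hydrogen on a saturated chain carbon bound to an oxygen next to a carbonyl group so methoxycarbonyl becomes propoxycarbonyl.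

Going by the values given here, one measured step bears on this change. The step of a 3.6-fold higher number from compound 2 to compound 3 (0.55 log units; beyond the scatter) is modest but beyond the scatter, and it comes from hydrogen in place of methyl on that same chain carbon. Read in reverse, the longer chain of compound 2 goes with the lower number. A single step cannot show whether this trend continues with a longer chain, so the expectation stays cautious. A modest move towards a lower number is expected in this assay and should be somewhat smaller than the measured step, and it could fall within the scatter. In numbers, the estimate is a 2.3-fold lower number from compound 3 to compound 4 (0.36 log units; beyond the scatter) as the expected step. For compound 4 the expected value is 25 nM with an estimated range from 9 nM to 75 nM in this assay.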

Compound 4, half-maximal inhibitory concentration: 29 nM
For compound 4 the middle estimate is 1.2-fold (0.06 log units) below the measured one, within the range that was stated.
By their numbers in this assay, from the lowest: compounds 2, 4 and 3 (each within the scatter of the next, the first and the last beyond it); then compound 1.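

The change from methoxycarbonyl to propoxycarbonyl gives a 2.0-fold lower number from compound 3 to compound 4 (0.29 log units; within the scatter) in this assay and so, taken alone, cannot be told apart from the ordinary differences between repeat measurements. The comparison with the neighbouring chain length gives a 1.8-fold higher number from compound 2 to compound 4 (0.26 log units; within the scatter) and likewise separates propoxycarbonyl from the ethoxycarbonyl group of compound 2 by no more than that scatter. For the compounds shown here, only the shortening step, a 3.6-fold higher number from compound 2 to compound 3 (0.55 log units; beyond the scatter) remains beyond the scatter, and with compound 4 lying within the scatter of both neighbours, these three compounds show neither a continued trend with chain length nor a reversal, which is more than the single earlier step could reveal.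

From the compounds shown here alone, whether a longer chain such as butoxycarbonyl, a benzyloxycarbonyl group or a free carboxylic acid would keep a number in this range remains open, as does whether propoxycarbonyl would behave the same way with the fluorine pattern of compound 1. No measurement offered here explains how the chain length at this position influences the result.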